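This account rests on a few compounds, and the source may have more. Where it says the series, first, only, none or still open, it means among the compounds named here.

Measured compounds:
compound 1, `COc1ccccc1Oc1ccc2c(NCCCNCc3ccco3)ccnc2c1` — 9.28
compound 2, `COc1cccc(CNCCCNc2ccnc3cc(-c4ccc(C(F)(F)F)cc4)ccc23)c1O` — 9.47
compound 3, `COc1ccc(F)cc1CNCCCNc1ccnc2cc(CC(C)C)ccc12` — 9.47

In a physicochemical assay for acid dissociation, compound 1 gives 9.28. Compound 2 returns 9.47, and compound 3 returns 9.47; compound 1 sits at the lower end of the three numbers, but the gaps to compound 2 and to compound 3 both lie within the scatter, so no ordering among the three can be read. Among the compounds with values here, all three share the same core and the same chain, and none of them forms a one-place pair with another, so no measured step is available.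

Compound 4, `c1ccc(Cc2ccc3c(NCCCNCc4ccco4)ccnc3c2)cc1`, is compound 1 with one change: benzyl in place of 2-methoxyphenoxy on an aromatic carbon. The rest of the structure is unchanged. With nothing else to go on, the step from compound 1 to compound 4 in this assay is expected to be small, in either direction, and most likely not beyond the scatter. The estimate for compound 4 is 9.35, with a range of 9 to 9.7, which means an expected step of a number 0.07 log units higher from compound 1 to compound 4 (within the scatter).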

Compound 4, acid dissociation constant: 9.47
Estimate against measurement, compound 4: 0.12 log units below, within the range that was stated.
By their numbers in this assay, from the lowest: compounds 1, 2, 3 and 4 (each within the scatter of the next).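

In this assay, within the data shown here, benzyl in place of 2-methoxyphenoxy on this aromatic carbon gives a number 0.19 log units higher from compound 1 to compound 4 (within the scatter) and is the first one-place comparison, which the earlier compounds could not provide. The oxygen atoms and hydrogen-bond acceptors of the leaving group are absent from benzyl, yet the two compounds cannot be separated in this read-out, so this one exchange at this position leaves no readable mark. Among these compounds, nothing measured so far bears on why this is so.

As far as these compounds go, whether an amine or a carboxylic acid on this same aromatic carbon would give a step beyond the scatter remains open. Also open, from the compounds shown here alone, is whether a longer chain in place of the shared chain would give such a step.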